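Series notes: 2-cyanophenyl on the amide-type nitrogen

The source may hold more compounds than are shown below. What is called first, only, known or untested is meant among the compounds shown, and "the series" means these compounds.

Within the data shown here, in a functional assay on Shh Light II cells (Mus musculus) for inhibition, read by a luciferase reporter (a lower number here means a stronger inhibitor, a higher number a weaker inhibitor), compound 2 (`O=C(NC1CC[S+]([O-])CC1)N1CCC(c2nc(-c3ccc4ccccc4n3)no2)CC1`) gives 850 nM, the lower of the two numbers so far, while compound 1 (`O=C(N1CCC(c2nc(-c3ccc4ccccc4n3)no2)CC1)N1CCCc2ccccc21`) gives 2300 nM. The next structure is compound 3 (`N#Cc1ccccc1NC(=O)N1CCC(c2nc(-c3ccc4ccccc4n3)no2)CC1`), with this change from compound 2: a group of 8 heavy atoms (7 carbon, 1 nitrogen; one six-membered aromatic ring of carbon only) in place of a group of 7 heavy atoms (5 carbon, 1 oxygen, 1 sulfur; one six-membered non-aromatic ring with 1 hetero atom), on an amide-type nitrogen. Among the measured compounds shown here, only one measured step bears on it, a 2.7-fold lower number from compound 1 to compound 2 (0.43 log units; beyond the scatter), which is modest but beyond the scatter. That step bears only indirectly. The group lost in it also carried a six-membered aromatic ring of carbon only, as 2-cyanophenyl does, but it was a different group, attached on a carbonyl carbon. For the measured compounds named here, no measured compound holds a nitrile, so the data do not settle the direction. The higher number of compound 1 at 2300 nM allows a small upward drift, and a change of about the size of a 2.7-fold lower number from compound 1 to compound 2 (0.43 log units; beyond the scatter) is possible either way. The expected result is a 1.2-fold higher number from compound 2 to compound 3 (0.07 log units; within the scatter), so no shift beyond the scatter is expected in this assay. The estimate for compound 3 is 1000 nM, with an expected range of 250 nM to 4000 nM.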

Compound 3, half-maximal inhibitory concentration: 190 nM
The estimate for compound 3 lay 5.3-fold (0.72 log units) above the measured number; measured number below the stated range.
By their numbers in this assay, from the lowest: compound 3; then compound 2; then compound 1.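

In this assay, 2-cyanophenyl on the amide-type nitrogen gives a 4.5-fold lower number from compound 2 to compound 3 (0.65 log units; beyond the scatter) and so sets compound 3 as the most potent of the three, which shows that this position can do better than the sulfur-bearing six-membered ring of compound 2. Among these compounds, on the carbonyl carbon, (2-cyanophenyl)amino in place of 1,2,3,4-tetrahydroquinolin-1-yl gives a 12-fold lower number from compound 1 to compound 3 (1.08 log units; beyond the scatter), the largest step so far, so a six-membered aromatic ring of carbon only does not by itself fix the number: compound 1 holds such a ring and stays the weakest of the three. No measurement at hand offers an explanation for either step.

The share of the nitrile and the share of the aromatic ring in these steps stay unseparated, and a plain phenyl group on the amide-type nitrogen would be the direct comparison with compound 3. Also open, on these data alone, is whether the nitrile itself is the best choice on that ring, which a chlorine or methoxy group in its place would test against compound 3 in the same assay.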